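Inverting One Stereocentre on Compound 1

The source may report more compounds than this note shows. Statements on the series, on what has been measured and on what is new or still open speak of the compounds shown alone.

In a functional assay on A549 cells (Homo sapiens) for antiproliferative activity, read by luminescence and CellTiter-Glo, with a stated time of 48 h (a lower number here means a stronger inhibitor, a higher number a weaker inhibitor), compound 1 (`C[C@H](Cc1ccccc1)[C@H]1CCCC(=O)O1`) is reported only as a limit, > 100000 nM, and no number is known for it. Compound 3 (`COc1ccc(/C=C/[C@H]2CC=CC(=O)O2)cc1`) is likewise reported only as a limit, > 100000 nM, in the same test. Compound 2 (`O=C1C=CC[C@@H](/C=C/C2CCCCC2)O1`) is the only one of the three with a measured number, 68600 nM, in that test. The set thus shows (the limit of > 100000 nM in this assay, at which 2 of the 3 values shown sit), and compound 1 is one of the two at that limit.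

Compound 4 (`C[C@@H](Cc1ccccc1)[C@H]1CCCC(=O)O1`) is the next to be tested, and its change from compound 1 is the two compounds have the same atoms and bonds and differ only in configuration as drawn: 1 of 2 stereo elements differ; a stereocentre at a saturated chain carbon is drawn R in compound 1 and S in compound 4. Among the measured compounds shown here, no measured pair here shows what such a change does. The expectation therefore rests on compound 1 alone, with its limit of > 100000 nM as the starting point. In this assay, the expected outcome is a number no higher from compound 1 to compound 4 (the limit leaves the size open), with no shift in either direction beyond the usual scatter. The estimate for compound 4 is 100000 nM, with an expected range from 60000 nM to 150000 nM.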

Compound 4, half-maximal inhibitory concentration: > 100000 nM
Compound 4: no number, only a limit (the forecaster's own chance of this, stated with the estimate: 80%); the middle value sits exactly at the limit.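

Compound 1 and compound 4 are both reported only as limits in this assay, and no step can be read between them. The compounds shown leave open what inverting the stereocentre at a saturated chain carbon does to antiproliferative activity: neither configuration has a number.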